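A few compounds are considered here, and "the series" means these few. Any claim that something is new, unique, unknown or untested is made for them only; others in the source may bear on it.

Going by the values given here, compound 2 `CNC1CCN(c2ncnc3[nH]cc(-c4cccc(Cl)c4)c23)CC1` is one of only two compounds measured so far in an assay for inhibition of serine/threonine-protein kinase 4 (Homo sapiens), read by luminescence and ADP-Glo, in the presence of a further agent that is not named here; a lower number here means a stronger inhibitor, a higher number a weaker inhibitor. In that assay compound 2 gives 148 nM, which places it at the top of the two numbers recorded. The other compound, compound 1 `OCCCNc1ncnc2[nH]cc(-c3cccc(Cl)c3)c12`, gives 94 nM in this assay, and the step of a 1.6-fold higher number from compound 1 to compound 2 (0.20 log units; within the scatter) lies within the scatter, so on these numbers the two compounds cannot be told apart.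

Compound 3 `CC1(O)CCN(c2ncnc3[nH]cc(-c4cccc(Cl)c4)c23)CC1` has not yet been measured. It differs from compound 2 in one place: 4-hydroxy-4-methylpiperidin-1-yl in place of 4-(methylamino)piperidin-1-yl on an aromatic carbon. Among the compounds with values here, no measured step changes this part of the molecule. Within the data shown here, the only step in hand, a 1.6-fold higher number from compound 1 to compound 2 (0.20 log units; within the scatter), replaces the entire group on the same aromatic carbon and stays within the scatter, which hints that this position accepts change, but it says nothing direct about swapping the methylamino for a hydroxyl and a methyl. The step expected here, a 1.4-fold higher number from compound 2 to compound 3 (0.13 log units; within the scatter), is therefore small, with no clear direction beyond the scatter. Compound 3 is estimated at 200 nM in this assay, within a range from 70 nM to 600 nM.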

Compound 3, half-maximal inhibitory concentration: 145 nM
Beside the measured number, compound 3's estimate is 1.4-fold (0.14 log units) above it; the range from low to high includes it.
By their numbers in this assay, from the lowest: compounds 1, 3 and 2 (each within the scatter of the next).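

In this assay, going by these compounds alone, the step to 4-hydroxy-4-methylpiperidin-1-yl gives a 1.0-fold lower number from compound 2 to compound 3 (0.01 log units; within the scatter), the first direct look at a change within the piperidine group rather than a replacement of the whole group. The two groups have the same counts of heavy atoms, hydrogen-bond donors and hydrogen-bond acceptors, and the methylamino nitrogen gives way to a hydroxyl oxygen with an added methyl, yet the numbers cannot be told apart. The open-chain (3-hydroxypropyl)amino group also cannot be separated from the new group, with a 1.5-fold higher number from compound 1 to compound 3 (0.19 log units; within the scatter), so all three groups on this aromatic carbon fall within the scatter of one another, and no available evidence explains this.

Going by these compounds, it remains open whether a piperidine carrying neither a hydroxyl nor an amine, a carboxylic acid or a longer chain on this aromatic carbon would stay within the same range. All three compounds share the rest of the molecule, so they say nothing about how changes elsewhere on the shared core would read.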